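Removing the Methyl from Compound 2

A few compounds are considered here, and "the series" means these few. Any claim that something is new, unique, unknown or untested is made for them only; others in the source may bear on it.

Measured compounds:
Compound 1, `CC/C=C\COC1(c2ccc(Cl)cc2)SC=C(C)n2c1noc2=O`: in a functional assay on A2780/DX3 cells (Homo sapiens) for antiproliferative activity, read by MTT assay, with a stated time of 3 days (on this read-out higher numbers stand for weaker inhibition and lower numbers for stronger inhibition), compound 1 gives 103000 nM.
Compound 2, `CC1=CSC(O)(c2ccc(C)cc2)c2noc(=O)n21`: in this assay compound 2 gives > 100000 nM, which is a limit of the assay and not a number.
Compound 3, `CCCCOC1(c2ccc(Br)cc2)SC=C(C)n2c1noc2=O`: in this assay compound 3 gives 78000 nM.

Compound 2 therefore stands at the limit of > 100000 nM in this assay, at which 1 of the 3 values shown sits; its antiproliferative effect on these cells was too weak for the assay to return a number, while compound 1 and compound 3, which share the same core but carry different groups on it, return weak numbers of the same general kind.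

Compound 4, `CC1=CSC(O)(c2ccccc2)c2noc(=O)n21`, keeps the whole of compound 2 except for one change: hydrogen in place of methyl on an aromatic carbon. Taking away such a small group on an aromatic carbon of a six-membered aromatic ring of carbon only is among the slightest changes that can be made, and no pair of measured compounds here shows what any single change does to this read-out. In this assay the step is expected to be none beyond the scatter, in no particular direction.

Compound 4 is therefore expected to give about 120000 nM, with a range from 50000 nM to 300000 nM. This estimate means a step that the limit leaves unreadable from compound 2 to compound 4 that stays within the scatter, and it is expected that the assay will most likely again report only a limit.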

Compound 4, half-maximal inhibitory concentration: > 100000 nM
Compound 4: a limit, no number (the forecaster's own chance of this, stated with the estimate: 70%); the middle value does not contradict the limit.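

In this assay compound 4 gives > 100000 nM, which is a limit of the assay and not a number. Compound 2 also stands at a limit, so no step can be read between compound 2 and compound 4: the limit of > 100000 nM in this assay, at which 2 of the 4 values shown sit.

The compounds shown leave open whether hydrogen in place of methyl on an aromatic carbon changes the effect on these cells at all, and in which direction.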